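The source may report more compounds than this note shows. Statements on the series, on what has been measured and on what is new or still open speak of the compounds shown alone.

Measured compounds in a functional assay on U-373MG ATCC cells for inhibition, with U373 MG (Homo sapiens) as the target, read by MTT assay, with a stated time of 72 h; on this read-out lower numbers stand for stronger inhibition of growth and higher numbers for weaker inhibition of growth:

- compound 1 `CC(C)=CCC/C(C)=C/CC/C(C)=C/C(=O)NC(=N)N` gives 21000 nM
- compound 2 `CC(C)=CCC/C(C)=C/CC/C(C)=C/C(=O)NC(=N)NC(=O)/C=C(\C)CC/C=C(\C)CCC=C(C)C` gives 9200 nM
- compound 3 `CC(C)=CCC/C(C)=C/C(=O)NC(=N)N` gives 46000 nM

Compound 2 stands lowest of the three, with compound 1 nearest and compound 3 furthest. Compound 2 and compound 1 differ by a large part of the molecule; the difference between their two cores is not broken down here.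

Compound 3 is derived from compound 1 by one change, (hydrogen in place of 3-methylbut-2-en-1-yl on a saturated chain carbon bound to a double-bonded chain carbon), and this step reads a 2.2-fold higher number from compound 1 to compound 3 (0.34 log units; beyond the scatter).

Compound 4 `CC(C)=CCC/C(C)=C/CC/C(C)=C/C(=O)NC(=N)NC(=O)/C=C(\C)CCC=C(C)C` has not yet been measured in this assay. Compound 4 is related to compound 2 by hydrogen in place of 3-methylbut-2-en-1-yl on a saturated chain carbon bound to a double-bonded chain carbon, which is the same change as that from compound 1 to compound 3: the group that leaves, the hydrogen that enters and the place are described in the same words for both pairs. The change is thus seen once in measured form, and compound 4 would be its second occurrence in the series.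

For compound 4 the step is expected to resemble the earlier one, resting on compound 1 and compound 3 with a 2.2-fold higher number from compound 1 to compound 3 (0.34 log units; beyond the scatter) and on compound 2 with 9200 nM as the starting point. The expected step for compound 4 is a 2.2-fold higher number from compound 2 to compound 4 (0.34 log units; beyond the scatter). For the measured compounds named here, compound 4 is therefore estimated at 20000 nM, with a range from 9000 nM to 45000 nM, the width reflecting that only one measured pair supports the change.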

Compound 4, concentration for 50% growth inhibition: 35000 nM
Beside the measured number, compound 4's estimate is 1.8-fold (0.24 log units) below it; the measured number falls inside the stated range.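

On the core of compound 2, hydrogen in place of 3-methylbut-2-en-1-yl on a saturated chain carbon bound to a double-bonded chain carbon gives, in this assay, a 3.8-fold higher number from compound 2 to compound 4 (0.58 log units; beyond the scatter), so growth inhibition weakens in the same direction as it did on the core of compound 1. Set side by side, the two occurrences of the change do not separate in size: the same change on two cores in this assay, a 2.2-fold higher number (0.34 log units; beyond the scatter) from compound 1 to compound 3 and a 3.8-fold higher number (0.58 log units; beyond the scatter) from compound 2 to compound 4, 1.7-fold (0.24 log units) apart, within the scatter of two such steps
So in this series the change carries over from one core to the other in direction and, as far as repeated measurements can tell, in size, which supports treating it as a transferable step on these cores; it does not show that the step would hold on any further core, since it rests on just two pairs, and the numbers alone give no reason for the weakening.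

The compounds shown leave open what a longer chain than 3,7-dimethylocta-2,6-dien-1-yl would do at this place, and whether the step would repeat on the remaining long chain of compound 4. They also leave open whether the change keeps its direction and size with an amine or a carboxylic acid at the chain end in place of the present polar end.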